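The source may hold more compounds than are shown below. What is called first, only, known or untested is meant among the compounds shown, and "the series" means these compounds.

Measured in a functional assay on A549 cells (Homo sapiens) for inhibition, read by sulforhodamine B assay, with a stated time of 48 h; on this read-out higher numbers stand for weaker inhibition and lower numbers for stronger inhibition:
- Compound 1 `C=CCC(O)(c1ccc(OC)c(OC)c1OC)c1cccc2ccccc12`: 10700 nM
- Compound 2 `COc1ccc(C(O)(Cc2ccc(F)cc2)c2cccc3ccccc23)c(OC)c1OC`: 5940 nM
- Compound 3 `COc1ccc(/C(=C\c2ccc(F)cc2)c2cccc3ccccc23)c(OC)c1OC`: > 20000 nM (a limit of the assay, not a number)

Only compound 1 and compound 2 give true numbers, and these two lie within the scatter of each other. Compound 3 gives no number, only (the limit of > 20000 nM in this assay, at which 1 of the 3 values shown sits).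

The next compound to be measured is compound 4 `CCOC(=O)C(C)C(O)(c1ccc(OC)c(OC)c1OC)c1cccc2ccccc12`. Compared with compound 2, it carries 1-(ethoxycarbonyl)ethyl in place of 4-fluorobenzyl on a saturated chain carbon bound to two aromatic carbons and an oxygen on a saturated carbon.

Going by the values given here, one measured step bears on this change, since it also alters the group on that carbon: a 1.8-fold lower number from compound 1 to compound 2 (0.26 log units; within the scatter). No step beyond the scatter is therefore expected, though the new group has no ring, as in compound 1, so a small drift towards weaker inhibition is expected.

The expected change is a 1.5-fold higher number from compound 2 to compound 4 (0.18 log units; within the scatter).

For compound 4 the estimated value is 9000 nM, with an expected range from 3500 nM to 20000 nM.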

Compound 4, half-maximal inhibitory concentration: 4000 nM
Compound 4: middle estimate off by 2.3-fold (0.35 log units), on the high side; the range from low to high includes it.
By their numbers in this assay, from the lowest: compounds 4, 2 and 1 (each within the scatter of the next, the first and the last beyond it). At a limit, above all of these: compound 3.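

In this assay, the position on the saturated chain carbon bound to two aromatic carbons and an oxygen accepts a group with no ring in place of 4-fluorobenzyl, with a 1.5-fold lower number from compound 2 to compound 4 (0.17 log units; within the scatter), so the six-membered aromatic ring of that group is not needed here to keep this level of inhibition. Among ring-free groups at this carbon, 1-(ethoxycarbonyl)ethyl in place of allyl gives a 2.7-fold lower number from compound 1 to compound 4 (0.43 log units; beyond the scatter), the first step at this position to pass beyond the scatter, though only a modest one. Nothing among the data shown accounts for this step.

On these data alone, it remains open whether the ester or the branching methyl of the new group carries that step. A carboxylic acid or an amide at the same carbon would help separate the two.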